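Thiophene Replacement for Thiazole in a Cytotoxicity Series

The source may report more compounds than this note shows. Statements on the series, on what has been measured and on what is new or still open speak of the compounds shown alone.

Compound 3 `C[C@H]1[C@H](NCc2cncs2)C[C@H]2C[C@@H]1C2(C)C` carries a 1,3-thiazol-5-yl group on the saturated chain carbon bound to the amine nitrogen. In an ADME assay on MDCK cells (Canis lupus familiaris) for cytotoxicity, read by microscopy, with a stated time of 48 h (a higher number here means that more compound is tolerated, a lower number that less compound is tolerated), compound 3 gives only a limit, > 100000 nM, so no number is known for it. Compound 1 `C[C@H]1[C@H](NCc2sccc2Br)C[C@H]2C[C@@H]1C2(C)C` gives 50000 nM in this assay, and compound 2 `CCOc1ccsc1CN[C@@H]1C[C@H]2C[C@@H]([C@H]1C)C2(C)C` gives 50000 nM. The step of no change at the digits printed from compound 1 to compound 2 (within the scatter) involved ethoxy in place of bromo on an aromatic carbon. The step of an at least 2.0-fold higher number from compound 1 to compound 3 (0.30 log units; that floor lies within the scatter) ran up to the limit (the limit of > 100000 nM in this assay, at which 1 of the 3 values shown sits), so its true size is open.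

Compound 4 `Cc1ccsc1CN[C@@H]1C[C@H]2C[C@@H]([C@H]1C)C2(C)C` differs from compound 3 by 3-methylthiophen-2-yl in place of 1,3-thiazol-5-yl on a saturated chain carbon bound to an amine nitrogen. This change bears most on the step from compound 1 to compound 3, which it in effect reverses, since compound 4 returns to a substituted thiophene of the kind found in compound 1 and compound 2. On that basis a lower number is expected for compound 4 in this assay, of the size an at least 2.0-fold lower number from compound 3 to compound 4 (0.30 log units; that floor lies within the scatter), landing near the values of compound 1 and compound 2. The estimate for compound 4 in this assay is therefore 50000 nM, with a range from 25000 nM to 100000 nM.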

Compound 4, minimum cytotoxic concentration: 10000 nM
For compound 4 the middle estimate is 5.0-fold (0.70 log units) above the measured one, and the stated range ends above it.
By their numbers in this assay, from the lowest: compound 4; then compounds 1 and 2 (each within the scatter of the next). At a limit, above all of these: compound 3.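

In this assay, the group on the thiophene turns out to matter: bromo and ethoxy had shown no change within the scatter, yet methyl in place of bromo gives a 5.0-fold lower number from compound 1 to compound 4 (0.70 log units; beyond the scatter), and methyl in place of ethoxy gives a 5.0-fold lower number from compound 2 to compound 4 (0.70 log units; beyond the scatter). Putting 3-methylthiophen-2-yl in place of 1,3-thiazol-5-yl on a saturated chain carbon bound to an amine nitrogen gives an at least 10-fold lower number from compound 3 to compound 4 (1.00 log units; beyond the scatter), a step beyond the scatter, whereas the floor of the step from compound 1 to compound 3 lay within it. Compound 3 still stands at a limit and not at a number, so the full size of this step remains unknown: the limit of > 100000 nM in this assay, at which 1 of the 4 values shown sits.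

The compounds shown leave open whether methyl stands alone among small groups on the thiophene, which a chloro group or an amine in place of the methyl would test. They also leave open how much of the step from compound 3 to compound 4 belongs to the ring and how much to the methyl, a question that a 1,3-thiazol-5-yl group carrying a methyl would address.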